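The source may report more compounds than this note shows. Statements on the series, on what has been measured and on what is new or still open speak of the compounds shown alone.

Working notes on the series around the shared core of compound 1, `CC1CCN(C2CCN(S(=O)(=O)c3ccc(C(C)(C)C)cc3)CC2)CC1`. In a functional assay on DLD-1 cells (Homo sapiens) for antiproliferative activity, read by CellTiter-Glo, with a stated time of 72 h (a higher number here means a weaker inhibitor, a lower number a stronger inhibitor), compound 1 reaches only the limit of > 5000 nM, recorded at the limit of > 5000 nM in this assay, at which 1 of the 3 values shown sits. Compound 2, `CC1CCN(C2CCN(S(=O)(=O)c3cccc(-c4ccc(F)cc4)c3)CC2)CC1`, gives 12 nM in this assay. Compound 3, `CC1CCN(C2CCN(S(=O)(=O)c3ccc(F)cc3F)CC2)CC1`, gives 102 nM in this assay, a gap to compound 2 that lies beyond the scatter, so compound 2 holds the lowest number of the two measured values.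

Compound 4, `COc1ccc(-c2cccc(S(=O)(=O)N3CCC(N4CCC(C)CC4)CC3)c2)cc1`, differs from compound 2 by methoxy in place of fluoro on an aromatic carbon. Within the data shown here, no measured pair in the set shows this change, so no direction is given by the data. The step from compound 2 to compound 4 in this assay is expected to stay small, a 1.7-fold higher number from compound 2 to compound 4 (0.22 log units; within the scatter), within or near the scatter. Compound 4 is estimated at 20 nM, with a range of 6 nM to 70 nM.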

Compound 4, half-maximal inhibitory concentration: 23 nM
Beside the measured number, compound 4's estimate is 1.2-fold (0.06 log units) below it; the measured number falls inside the stated range.
By their numbers in this assay, from the lowest: compounds 2 and 4 (each within the scatter of the next); then compound 3. At a limit, above all of these: compound 1.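

In this assay, methoxy in place of fluoro on this aromatic carbon, para to a large group, gives a 1.9-fold higher number from compound 2 to compound 4 (0.28 log units; within the scatter). Among these compounds, this is the first measured change at this position, and it shows that 4-fluorophenyl and 4-methoxyphenyl cannot be told apart here. No information at hand bears on a reason for this result. The compounds shown leave open how an amine, a carboxylic acid or a longer alkoxy chain on this carbon would read in this assay.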